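The source may hold more compounds than are shown below. What is called first, only, known or untested is meant among the compounds shown, and "the series" means these compounds.

Measured in an assay on HEK293 cells for agonist activity at transient receptor potential cation channel subfamily M member 8 (Homo sapiens), read by fluorescence and calcium flux, with a stated time of 15 min (a higher number here means that more compound is needed for the effect, a lower number that less compound is needed), so far:
compound 1 `CCC(C)N(Cc1cccs1)C(=O)COc1ccc(C)cc1` gives 2000 nM;
compound 2 `Cc1ccc(OCC(=O)N(Cc2cccs2)c2c(C)n[nH]c2C)cc1` gives 0.3 nM.

Within the data shown here, compound 2 holds the lowest number of the two, and its only neighbour is compound 1; the step of a 6700-fold lower number from compound 1 to compound 2 (3.82 log units; beyond the scatter) lies far beyond the scatter. Compound 3 `COCCN(Cc1cccs1)C(=O)COc1ccc(C)cc1` has not yet been measured. It differs from compound 2 in one place: 2-methoxyethyl in place of 3,5-dimethyl-1H-pyrazol-4-yl on an amide-type nitrogen. A single measured step bears on this position, namely a 6700-fold lower number from compound 1 to compound 2 (3.82 log units; beyond the scatter), in which a sec-butyl group with no ring gave way to the 3,5-dimethyl-1H-pyrazol-4-yl ring and the number fell sharply. Compound 3 moves in the opposite direction, putting a 2-methoxyethyl chain with no ring onto the amide-type nitrogen. Among the measured compounds shown here, that chain is not sec-butyl, so the data do not show how closely compound 3 will track compound 1, but the one relevant step suggests most of the gain seen in compound 2 would be given back. The expected step in this assay is therefore large and upward, about a 5000-fold higher number from compound 2 to compound 3 (3.70 log units; beyond the scatter). Compound 3 is estimated to give 1500 nM in this assay, with a range from 150 nM to 15000 nM.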

Compound 3, half-maximal effective concentration: 400 nM
Compound 3: the middle estimate sits 3.8-fold (0.57 log units) above what was measured; measured number inside the range.
By their numbers in this assay, from the lowest: compound 2; then compound 3; then compound 1.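

In this assay, the 3,5-dimethyl-1H-pyrazol-4-yl ring now stands against a second group with no ring on the amide-type nitrogen: putting 2-methoxyethyl in its place brings a 1300-fold higher number from compound 2 to compound 3 (3.12 log units; beyond the scatter), so the low number of compound 2 is not kept by this chain. The two groups without a ring are not interchangeable either, since 2-methoxyethyl in place of sec-butyl gives a 5.0-fold lower number from compound 1 to compound 3 (0.70 log units; beyond the scatter), a modest step that is still beyond the scatter but far smaller than the step on leaving the ring. Across these three compounds, most of the spread therefore goes with the difference between the ring and the two chains, and less of it with the difference between the chains, though no evidence here gives a reason for either step.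

Going by these compounds, it remains open whether a plain phenyl ring or a pyrazol-4-yl ring without its two methyl groups would keep the low number of compound 2, which would show how much depends on the ring and how much on its substituents. On these data alone, it is also open how a longer ether chain, or a chain ending in an amine, would compare with 2-methoxyethyl.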